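The source may report more compounds than this note shows. Statements on the series, on what has been measured and on what is new or still open speak of the compounds shown alone.

Three compounds have been measured in an assay on membranes from liver for displacement of a labelled ligand from Glucagon receptor (Mus musculus), read by scintillation counting, with a stated time of 60 min; on this read-out higher numbers stand for weaker inhibition and lower numbers for stronger inhibition:

compound 2 `CC(C)(C)CC[C@H](c1ccc(C(=O)NCc2nn[nH]n2)cc1)N1C(=O)C(c2cncc(Cl)c2)=N[C@]12CC[C@@H](C(C)(C)C)CC2`, 84 nM
compound 3 `CC(C)CC[C@H](c1ccc(C(=O)NCc2nn[nH]n2)cc1)N1C(=O)C(c2cc(Cl)cc(Cl)c2)=N[C@]12CC[C@@H](C(C)(C)C)CC2`, 280 nM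
compound 1 `CC(C)(C)[C@H]1CC[C@]2(CC1)N=C(c1ccc(C(F)(F)F)cc1)C(=O)N2Cc1ccc(C(=O)NCCC(=O)O)cc1`, 9600 nM

Compound 2 has the lowest number of the three, and both gaps to it lie beyond the usual scatter, so it is the strongest binder among them. Compound 4 `CC(C)(C)CC[C@H](c1ccc(C(=O)NCc2nn[nH]n2)cc1)N1C(=O)C(c2cnccc2C(F)(F)F)=N[C@]12CC[C@@H](C(C)(C)C)CC2` keeps everything in compound 2 except one group: 4-(trifluoromethyl)pyridin-3-yl in place of 5-chloropyridin-3-yl on a carbon with a double bond to nitrogen. For the measured compounds named here, no measured pair shows this exact swap, so the size of the step in this assay is uncertain; a small move, perhaps toward a weaker number, is expected. Compound 4 is therefore estimated at 150 nM, with a range from 50 nM to 500 nM. This estimate implies an expected step of a 1.8-fold higher number from compound 2 to compound 4 (0.25 log units; within the scatter).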

Compound 4, half-maximal inhibitory concentration: 96 nM
The estimate for compound 4 lay 1.6-fold (0.19 log units) above the measured number; the measured number falls inside the stated range.
By their numbers in this assay, from the lowest: compounds 2 and 4 (each within the scatter of the next); then compound 3; then compound 1.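

In this assay the swap to 4-(trifluoromethyl)pyridin-3-yl from 5-chloropyridin-3-yl gives a step (a 1.1-fold higher number from compound 2 to compound 4 (0.06 log units; within the scatter)) that lies within the scatter. This position on the carbon with a double bond to nitrogen therefore accepts the larger group, with its substituent placed differently on the pyridine ring, without a change that this read-out can resolve. No measurement here bears on why the two groups read alike. On these data alone, it remains open whether the position also accepts a plain phenyl ring, or a pyridine ring carrying an amine or a carboxylic acid.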